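The source may report more compounds than this note shows. Statements on the series, on what has been measured and on what is new or still open speak of the compounds shown alone.

Measured in an ADME assay on A549 cells (Homo sapiens) for cytotoxicity, read by resazurin assay, with a stated time of 48 h; a higher number here means that more compound is tolerated, a lower number that less compound is tolerated:
- compound 1 `O=C(Nc1ccc(NCc2cc(Cl)cc(C(F)(F)F)c2)cc1Cl)c1cc(Cl)ccc1O`: 30900 nM
- compound 2 `O=C(Nc1ccc(NCc2cc(F)cc(C(F)(F)F)c2)cc1Cl)c1cc(Cl)ccc1O`: 30900 nM

In this assay compound 2, at 30900 nM, stands level with compound 1. Compound 3 `O=C(Nc1ccc(NCc2cc(C(F)(F)F)cc(C(F)(F)F)c2)cc1Cl)c1cc(Cl)ccc1O` has trifluoromethyl in place of fluoro on an aromatic carbon, meta to a trifluoromethyl group: trifluoromethyl in place of fluoro on an aromatic carbon. Among the compounds with values here, only one measured step bears on this change, and it concerns the same place on the ring: no change at the digits printed from compound 1 to compound 2 (within the scatter). Within the data shown here, that swap of chloro for fluoro moved nothing, but a single step is thin evidence, and no compound measured so far carries the larger trifluoromethyl group here. No step beyond the scatter is therefore expected in this assay, and no direction can be favoured with confidence. The estimate is a 1.1-fold lower number from compound 2 to compound 3 (0.04 log units; within the scatter), which is an expected step and not a measured one. Compound 3 is expected at 28000 nM, with an estimated range from 12000 nM to 60000 nM.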

Compound 3, half-maximal cytotoxic concentration: 92800 nM
For compound 3 the middle estimate is 3.3-fold (0.52 log units) below the measured one; the measured number lies above the stated range.
By their numbers in this assay, from the lowest: compounds 1 and 2 (each within the scatter of the next); then compound 3.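

In this assay, this position turns out not to be indifferent to its substituent, even though chloro and fluoro could not be told apart. Trifluoromethyl gives a 3.0-fold higher number from compound 2 to compound 3 (0.48 log units; beyond the scatter) when it replaces fluoro and a 3.0-fold higher number from compound 1 to compound 3 (0.48 log units; beyond the scatter) when it replaces chloro, so more compound is tolerated with this group than with either halogen. Nothing available explains this rise.

Within the data shown here, with only three groups compared at this carbon, it remains open whether the rise belongs to trifluoromethyl itself or would also appear with other groups of several heavy atoms. As far as these compounds go, how a nitrile, a methoxy group or an amine would behave here is unknown, as is whether the same change would have the same effect on a different core.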